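Methyl on the phenyl: toxicity of sulfonamide analogues

The compounds below may be only part of what the source reports. "The series", "measured", "known", "first", "only" and "open" are said of these compounds alone.

Measured compounds:
Compound 1, `O=c1[nH]cc(S(=O)(=O)Nc2ccccc2-c2cn(-c3ccccc3)nn2)c(=O)[nH]1`, 10600 nM
Compound 2, `Cc1cccc(-n2cc(-c3ccccc3NS(=O)(=O)c3c[nH]c(=O)[nH]c3=O)nn2)c1`, 21900 nM
Compound 3, `O=c1[nH]cc(S(=O)(=O)Nc2ccc(-c3cn(-c4ccccc4)nn3)cc2)c(=O)[nH]1`, "not toxic" (no number reported)

In an ADME assay on L02 cells (Homo sapiens) for cytotoxicity, read by MTT assay, with a stated time of 24 h (on this read-out lower numbers stand for higher toxicity in this test and higher numbers for lower toxicity in this test), compound 1 gives 10600 nM, and compound 2 gives 21900 nM. The two differ by one change, (methyl in place of hydrogen on an aromatic carbon), which gave a 2.1-fold higher number from compound 1 to compound 2 (0.32 log units; beyond the scatter). Compound 3 shares its atoms with compound 1 but has them joined differently; how the two cores differ is not broken down here. In this assay compound 3 gave no single number, only the report "not toxic" (no number reported).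

Compound 4, `Cc1ccccc1-n1cc(-c2ccc(NS(=O)(=O)c3c[nH]c(=O)[nH]c3=O)cc2)nn1`, has not yet been tested. It differs from compound 3 by methyl in place of hydrogen on an aromatic carbon. Among the compounds with values here, this is the same kind of change as the one from compound 1 to compound 2, but the place is not identical: there the methyl sits meta to a large group, here ortho to a large group. Because a 2.1-fold higher number from compound 1 to compound 2 (0.32 log units; beyond the scatter) pointed toward lower toxicity, and because compound 3 was already reported as "not toxic" (no number reported), compound 4 is expected to be at most weakly toxic, with a fair chance that again no number is reported. The estimated value for compound 4 in this assay is 50000 nM, within 20000 nM to 200000 nM.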

Compound 4, half-maximal cytotoxic concentration: "not toxic" (no number reported)
No number was reported for compound 4; the estimate stays without a comparison.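

In this assay, within the data shown here, compound 3 gives "not toxic" (no number reported) and compound 4 gives "not toxic" (no number reported), and with no number on either side, no step between the two can be read. The compounds shown leave open whether phenyl to 2-methylphenyl shifts toxicity on this core at all, as methyl did between compound 1 and compound 2. No evidence on this result is available.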